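This account rests on a few compounds, and the source may have more. Where it says the series, first, only, none or still open, it means among the compounds named here.

Measured so far in an ADME assay on NHDF cells (Homo sapiens) for cytotoxicity, read by MTT assay, with a stated time of 72 h; a higher number here means a weaker inhibitor, a lower number a stronger inhibitor:
- compound 1 `COc1ccc(/C=C2\CCC/C(=C\c3ccc(OC)c(OC)c3)C2=O)cc1`: 30900 nM
- compound 2 `COc1ccc(/C=C2\CCC/C(=C\c3cccc(Cl)c3Cl)C2=O)cc1OC`: 18500 nM
- compound 3 `COc1ccc(/C=C2\CCC/C(=C\c3ccc(O)c(Cl)c3)C2=O)cc1OC`: 21900 nM

Compound 3 cannot be told apart from the other two compounds on these numbers. The measurements show a 1.2-fold higher number from compound 2 to compound 3 (0.07 log units; within the scatter) and a 1.4-fold lower number from compound 1 to compound 3 (0.15 log units; within the scatter).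

The next compound, compound 4 `COc1cc(/C=C2\CCC/C(=C\c3ccc(OC)c(OC)c3)C2=O)ccc1O`, differs from compound 3 at a single place, with methoxy in place of chloro on an aromatic carbon, ortho to a hydroxy group: methoxy in place of chloro on an aromatic carbon. The whole group therefore changes from 3-chloro-4-hydroxyphenyl to 4-hydroxy-3-methoxyphenyl.

Going by the values given here, no measured step makes this exact exchange. The closest evidence comes from the other changes of aryl group on the same kind of carbon, a 1.7-fold lower number from compound 1 to compound 2 (0.22 log units; within the scatter) and a 1.4-fold lower number from compound 1 to compound 3 (0.15 log units; within the scatter), and both stayed small. A shift beyond the scatter is therefore not expected, in either direction. The expected step is a 1.1-fold higher number from compound 3 to compound 4 (0.04 log units; within the scatter).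

For compound 4, the estimated value is 24000 nM, with an expected range from 12000 nM to 45000 nM.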

Compound 4, half-maximal inhibitory concentration: 13700 nM
Estimate against measurement, compound 4: 1.8-fold (0.24 log units) above, and the stated range covers the measured number.
By their numbers in this assay, from the lowest: compounds 4, 2, 3 and 1 (each within the scatter of the next, the first and the last beyond it).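

In this assay the exchange of chloro for methoxy on this aromatic carbon, ortho to a hydroxy group, stays within the scatter (a 1.6-fold lower number from compound 3 to compound 4 (0.20 log units; within the scatter)). So a one-atom halogen and a two-atom oxygen group are not told apart at this place, at least with the hydroxy group present. Going by these compounds alone, the 4-hydroxy-3-methoxyphenyl group is also not told apart from 2,3-dichlorophenyl (a 1.4-fold lower number from compound 2 to compound 4 (0.13 log units; within the scatter)), yet it gives the first step in this set beyond the scatter, a modest one, when it replaces 4-methoxyphenyl (a 2.3-fold lower number from compound 1 to compound 4 (0.35 log units; beyond the scatter)).

Nothing measured here gives a reason for these steps. Still open, as far as these compounds go, is whether an ethoxy group, an amine or a carboxylic acid at this place would move the number beyond the scatter, and whether methoxy keeps its effect without the neighbouring hydroxy group.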